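This account rests on a few compounds, and the source may have more. Where it says the series, first, only, none or still open, it means among the compounds named here.

Working notes on three compounds with a shared core, all measured in a physicochemical assay for solubility, read by spectrophotometry, in phosphate buffer, with a stated time of 18 h, at pH 7.4; on this read-out higher numbers stand for higher solubility and lower numbers for lower solubility. Compound 1 `CCc1ccc(-c2nc3c(c(C)nn3-c3ccccc3)c(-c3ccccc3O)c2C#N)cc1` gives 3100 nM, compound 2 `Cc1nn(-c2ccccc2)c2nc(-c3ccc4ccccc4c3)c(C#N)c(-c3ccccc3O)c12` gives 1800 nM, and compound 3 `Cc1nn(-c2ccccc2)c2nc(-c3ccc(C#N)cc3)c(C#N)c(-c3ccccc3O)c12` gives 1700 nM. Compound 3 therefore stands level with the other two, since its gaps to both lie within the scatter and no order can be read among the three.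

The next compound is compound 4 `Cc1nn(-c2ccccc2)c2nc(-c3ccc([N+](=O)[O-])cc3)c(C#N)c(-c3ccccc3O)c12`, with nitro in place of cyano on an aromatic carbon, para to a large group: nitro in place of cyano on an aromatic carbon. The same difference, cut one bond further out, reads 4-cyanophenyl to 4-nitrophenyl.

Among the measured compounds shown here, no measured compound carries nitro, so the evidence is indirect. Two measured steps change the group at this place: a 1.8-fold lower number from compound 1 to compound 3 (0.26 log units; within the scatter), and a 1.1-fold lower number from compound 2 to compound 3 (0.02 log units; within the scatter). The third step, a 1.7-fold lower number from compound 1 to compound 2 (0.24 log units; within the scatter), changes the aryl group as a whole. All three stay within the scatter, so no shift beyond the scatter is expected in this assay, and no direction can be assigned. The expected change is small, and the estimate is a 1.1-fold lower number from compound 3 to compound 4 (0.03 log units; within the scatter). Compound 4 is estimated at 1600 nM, with an expected range of 750 nM to 3300 nM.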

Compound 4, solubility: 6000 nM
Compound 4: the middle estimate sits 3.8-fold (0.57 log units) below what was measured, and the stated range ends below it.
By their numbers in this assay, from the lowest: compounds 3, 2, 1 and 4 (each within the scatter of the next, the first and the last beyond it).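

In this assay, the group at this place, on an aromatic carbon para to a large group, now gives steps beyond the scatter: nitro in place of cyano gives a 3.5-fold higher number from compound 3 to compound 4 (0.55 log units; beyond the scatter) and 4-nitrophenyl in place of naphthalen-2-yl gives a 3.3-fold higher number from compound 2 to compound 4 (0.52 log units; beyond the scatter) in the same series, whereas all earlier steps stayed within it. The change is not equally readable against every group, since nitro in place of ethyl gives a 1.9-fold higher number from compound 1 to compound 4 (0.29 log units; within the scatter) and so leaves compound 1 and compound 4 level. The series therefore separates nitro from cyano and from naphthalen-2-yl but not from ethyl, and no measurement at hand bears on the reason for this separation.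

On these data alone, it remains open whether the higher number belongs to nitro alone or would also appear with an amine or a carboxylic acid at this place. As far as these compounds go, the rest of the shared core is the same in all four compounds, so it is also open whether the step from cyano to nitro would keep its size with a different group elsewhere on the core.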